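The source may hold more compounds than are shown below. What is called first, only, known or untested is meant among the compounds shown, and "the series" means these compounds.

Three compounds have been tested in a functional assay on the whole organism (strain Swiss albino) with Mus musculus as the target, in the maximal electroshock model, with a stated time of 0.5 h; on this read-out lower numbers stand for an effect already at smaller amounts and higher numbers for an effect only at larger amounts of compound:

Compound 1 `O=C(N/N=C/c1ccc(O)cc1)Nc1cccc2ccccc12` gives 100 mg/kg.
Compound 2 `O=C(N/N=C/c1ccccc1)Nc1cccc2ccccc12` gives 300 mg/kg.
Compound 3 `CN(C)c1ccc(/C=N/NC(=O)Nc2cccc3ccccc23)cc1` gives 100 mg/kg.

Compound 3 stands level with compound 1 at the digits printed, and these two share the lowest number of the three; the step of a 3.0-fold lower number from compound 2 to compound 3 (0.48 log units; beyond the scatter) sets compound 2 apart.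

Compound 4 `O=C(N/N=C/c1ccc([N+](=O)[O-])cc1)Nc1cccc2ccccc12` differs from compound 3 by nitro in place of dimethylamino on an aromatic carbon. Within the data shown here, two measured steps bear on a swap of groups at this aromatic carbon. The step of no change at the digits printed from compound 1 to compound 3 (within the scatter) shows that exchanging one group for another there left the number unchanged, while a 3.0-fold higher number from compound 1 to compound 2 (0.48 log units; beyond the scatter) and a 3.0-fold lower number from compound 2 to compound 3 (0.48 log units; beyond the scatter) show that only removing the group altogether moved it. Since compound 4 keeps a group in that place, the expected step is a 1.5-fold higher number from compound 3 to compound 4 (0.18 log units; within the scatter), within the scatter. Compound 4 is therefore estimated at 150 mg/kg, between 70 mg/kg and 300 mg/kg.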

Compound 4, minimum effective dose: 300 mg/kg
For compound 4 the middle estimate is 2.0-fold (0.30 log units) below the measured one; low and high end bracket the measured number.
By their numbers in this assay, from the lowest: compounds 1 and 3 (each within the scatter of the next); then compounds 2 and 4 (each within the scatter of the next).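

Nitro shows that keeping a group at this aromatic carbon is not enough to hold the number down in this assay: the swap for dimethylamino gives a 3.0-fold higher number from compound 3 to compound 4 (0.48 log units; beyond the scatter) and the swap for hydroxy gives a 3.0-fold higher number from compound 1 to compound 4 (0.48 log units; beyond the scatter) while the swap for hydrogen gives no change at the digits printed from compound 2 to compound 4 (within the scatter) at this place. The identity of the group therefore matters here, with hydroxy and dimethylamino on one side and nitro and hydrogen on the other. (Nothing measured here explains this split).

From the compounds shown here alone, whether methoxy, chlorine or a carboxylic acid at this place would join hydroxy and dimethylamino or nitro and hydrogen remains open.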